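This account rests on a few compounds, and the source may have more. Where it says the series, first, only, none or still open, it means among the compounds named here.

In a functional assay on NIH3T3 cells (Mus musculus) (a lower number here means that less compound is needed, a higher number that more compound is needed for the effect), compound 1 (`COC(=O)[C@H](CCSC)NC(=O)c1ccc(CNCc2c[nH]cn2)cc1-c1ccccc1C`) gives 25 uM as its measured value. Compound 2 (`N#Cc1ccc(Cn2cncc2CNc2ccc(C(=O)NCc3ccccc3)c(-c3ccccc3)c2)cc1`) gives > 10 uM as a limit of the assay, not a number. Compound 3 (`COC(=O)[C@H](CCSC)NC(=O)c1ccc(NCc2cncn2Cc2ccc(C#N)cc2)cc1-c1ccccc1`) differs from compound 2 in one place (1-(methoxycarbonyl)-3-(methylsulfanyl)propyl in place of benzyl on an amide-type nitrogen). Compound 1 also carries 1-(methoxycarbonyl)-3-(methylsulfanyl)propyl on its amide-type nitrogen and gives a real number, 25 uM, in this assay. Among the measured compounds shown here, no measured pair shows this change alone, so a move to a lower number is expected only tentatively. The expected step (an at least 6.6-fold lower number from compound 2 to compound 3 (0.82 log units; beyond the scatter)) is a rough estimate. For compound 3 the estimated value is 1.5 uM with an expected range from 0.2 uM to 12 uM as its likely span.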

Compound 3, concentration for half-maximal effect: > 10 uM
Compound 3 gave a limit, no number; the forecaster's own chance of this, stated with the estimate: 15%; middle value at least 6.6-fold (0.82 log units) away from the limit.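

Among the compounds shown here, compound 2 and compound 3 both give only a limit in this assay and no number, so no step between them can be read: the limit of > 10 uM in this assay, at which 2 of the 3 values shown sit. Going by these compounds, what stays open is whether 1-(methoxycarbonyl)-3-(methylsulfanyl)propyl in place of benzyl changes the true values of these two compounds at all.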